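Swapping hydroxy for amino on a cytotoxic scaffold

The source may hold more compounds than are shown below. What is called first, only, known or untested is meant among the compounds shown, and "the series" means these compounds.

Three compounds share a core and were tested in a functional assay on DU-145 cells (Homo sapiens) for cytotoxicity, read by CCK-8 assay and cell counting, with a stated time of 72 h; a lower number here means a stronger inhibitor, a higher number a weaker inhibitor. Compound 1, `COc1ccc(-c2cc3ccccc3c(-c3ccc(OC)cc3)n2)cc1`, gives only a limit in this assay, > 50000 nM, which is the limit of > 50000 nM in this assay, at which 1 of the 3 values shown sits. Compound 2, `COc1cc(OC)cc(-c2cc3ccccc3c(-c3ccc(O)cc3)n2)c1`, gives 4580 nM in this assay. Compound 3, `COc1ccc(-c2cc3cc(C)ccc3c(-c3cccc(O)c3)n2)cc1OC`, gives 6510 nM in this assay. The two numbers from compound 2 and compound 3 lie within the usual scatter of each other, so neither can be set apart from the other; compound 1 stands aside with its limit alone.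

Compound 4, `COc1ccc(-c2cc3cc(C)ccc3c(-c3cccc(N)c3)n2)cc1OC`, has not yet been measured in this assay. It differs from compound 3 by amino in place of hydroxy on an aromatic carbon. For the measured compounds named here, no pair among the measured compounds differs in exactly this way, so there is no measured step to lean on. Both groups carry one hydrogen-bond donor and one hydrogen-bond acceptor, and the change is small. The step from compound 3 to compound 4 is therefore expected to stay within the scatter, a 1.0-fold lower number from compound 3 to compound 4 (0.00 log units; within the scatter), with no clear direction. Compound 4 is estimated at 6500 nM in this assay, within a range from 2200 nM to 20000 nM.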

Compound 4, half-maximal inhibitory concentration: 4190 nM
For compound 4 the middle estimate is 1.6-fold (0.19 log units) above the measured one; measured number inside the range.
By their numbers in this assay, from the lowest: compounds 4, 2 and 3 (each within the scatter of the next). At a limit, above all of these: compound 1.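

For the compounds shown here, this is the only step so far that changes a single place. In this assay the change from 3-hydroxyphenyl to 3-aminophenyl gives a 1.6-fold lower number from compound 3 to compound 4 (0.19 log units; within the scatter) and so cannot be told apart from repeat measurements. On this aromatic carbon, then, the oxygen of the hydroxy group can give way to the nitrogen of an amino group with no readable change in the number, and the exchange keeps the count of one hydrogen-bond donor and one hydrogen-bond acceptor. Nothing in the data shown accounts for why the two groups read alike.

What the compounds shown leave open is whether this place tolerates groups of a different kind, such as a methyl group, a fluorine atom, a nitrile or an acetamide, which would show whether the hydrogen-bond donor matters here at all. A single step also cannot tell whether amino in place of hydroxy would read the same way on a compound with other groups around the shared core.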